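Lengthening the Hydroxycarbamoyl Chain Once More

This account rests on a few compounds, and the source may have more. Where it says the series, first, only, none or still open, it means among the compounds named here.

Compound 1 `O=C(CCNC(=O)c1cc(-c2ccc(F)cc2)[nH]n1)NO`: 46900 nM
Compound 2 `O=C(CCCNC(=O)c1cc(-c2ccc(F)cc2)[nH]n1)NO`: > 100000 nM (a limit, not a number)
Compound 3 `O=C(CCCCNC(=O)c1cc(-c2ccc(F)cc2)[nH]n1)NO`: > 100000 nM (a limit, not a number)

These three compounds share one core and differ only in the length of the chain that ends in the hydroxycarbamoyl group. All were tested in a functional assay on A549 cells (Homo sapiens) for antiproliferative activity, read by MTT assay, with a stated time of 96 h; a higher number here means a weaker inhibitor of growth, a lower number a stronger inhibitor of growth. As far as these compounds go, compound 3 stands at the limit of > 100000 nM in this assay, at which 2 of the 3 values shown sit, so its true value is unknown.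

The next compound is compound 4 `O=C(CCCCCNC(=O)c1cc(-c2ccc(F)cc2)[nH]n1)NO`, and the change is (hydroxycarbamoyl)methyl in place of hydroxycarbamoyl on a saturated chain carbon, four bonds along the chain from an amide-type nitrogen. In other words, 3-(hydroxycarbamoyl)propyl gives way to 4-(hydroxycarbamoyl)butyl.

Two measured steps of the same kind point the same way, towards weaker growth inhibition: an at least 2.1-fold higher number from compound 1 to compound 2 (0.32 log units; beyond the scatter), and an at least 2.1-fold higher number from compound 1 to compound 3 (0.32 log units; beyond the scatter). Both are at least modest, but their true sizes are hidden by the limit. The closest comparison gives no size at all: a step that the two limits leave unreadable from compound 2 to compound 3.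

With compound 2 and compound 3 both at a limit, there is no measured trend to extend, and no clear gain in this assay is expected. The expected change is a number no higher from compound 3 to compound 4 (the limit leaves the size open), a step that may well prove unreadable. The estimate for compound 4 is 100000 nM, with an expected range from 40000 nM to 200000 nM.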

Compound 4, concentration for 50% growth inhibition: 7090 nM
Compound 4: middle estimate off by 14-fold (1.15 log units), on the high side; measured number below the stated range.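

In this assay, lengthening the chain so that 4-(hydroxycarbamoyl)butyl replaces 3-(hydroxycarbamoyl)propyl gives the first real gain in this series, with an at least 14-fold lower number from compound 3 to compound 4 (1.14 log units; beyond the scatter), and the comparison with the next shorter chain gives an at least 14-fold lower number from compound 2 to compound 4 (1.14 log units; beyond the scatter). Compound 4 also passes the shortest chain shown, with a 6.6-fold lower number from compound 1 to compound 4 (0.82 log units; beyond the scatter), and its steps to all three other compounds lie beyond the scatter, so it is the strongest growth inhibitor of the four. Chain length therefore does not act in one direction across these compounds: lengthening the chain from compound 1 weakens growth inhibition, whereas the same kind of change at the long end strengthens it: the same change on two cores in this assay, an at least 2.1-fold higher number (0.32 log units; beyond the scatter) from compound 1 to compound 2 and an at least 14-fold lower number (1.14 log units; beyond the scatter) from compound 3 to compound 4, at least 30-fold (1.47 log units) apart, beyond the scatter of two such steps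

As far as these compounds go, the step from compound 2 to compound 3 cannot be read, and the steps from those two compounds to compound 4 have only a lower bound on their size, so how deep the loss of activity runs in the middle of the series stays unknown. From the compounds shown here alone, whether a longer chain than 4-(hydroxycarbamoyl)butyl, such as 5-(hydroxycarbamoyl)pentyl, would lower the number further or raise it again also remains open.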